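The compounds below may be only part of what the source reports. "The series", "measured", "known", "first", "only" and "open" are said of these compounds alone.

Working notes on the series. In an ADME assay on microsomes from liver (Mus musculus), read by LC-MS, using NADPH, with a stated time of 30 min, tested at 1 uM (a lower number here means that less of the compound is left, a higher number that more of the compound is left), compound 1 `Cc1ccc2cc([C@H](C)Nc3ncnc(N)c3C#N)c(-c3ccccc3)c(=O)n2c1` gives "not determined" (no result reported) and compound 2 `C[C@H](Nc1nc(N)nc(N)c1C#N)c1cc(=O)n2cc(F)ccc2c1-c1ccccc1` gives "not determined" (no result reported), so neither carries a result there. Compound 3 `C[C@H](Nc1ncnc(N)c1C#N)c1cc(=O)n2cc(F)ccc2c1-c1ccccc1` is the only member with a number there: in this assay compound 3 gives 69%, so compound 3 stands alone on the numbers shown, with nothing measured to set it against. Compound 4 `C[C@H](Nc1ncnc(N)c1C#N)c1cc(=O)n2cc(F)ccc2c1-c1cccc(F)c1` differs from compound 3 by fluoro in place of hydrogen on an aromatic carbon, meta to a large group. Within the data shown here, no step between measured compounds is available, and this change is small; the expected step from compound 3 to compound 4 in this assay is a number 1 percentage points higher from compound 3 to compound 4 (within the scatter), not beyond the scatter in either direction. Compound 4 is therefore estimated at 70%, within 50% to 88%.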

Compound 4, percent of the compound remaining: 83%
Compound 4: middle estimate off by 13 percentage points, on the low side; measured number inside the range.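

In this assay, among these compounds, the change from phenyl to 3-fluorophenyl gives a number 14 percentage points higher from compound 3 to compound 4 (beyond the scatter) and is the only step with numbers on both sides. A single fluoro in place of hydrogen on this aromatic carbon, meta to a large group, is thus enough to shift the read-out upward. Nothing measured here bears on why.

The compounds shown leave open whether a chloro or a methoxy group at this place would give a step of the same direction and size, and whether fluoro elsewhere on this ring would do the same.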